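Naphthalen-2-yl hydrazone analogue of compound 1

This account rests on a few compounds, and the source may have more. Where it says the series, first, only, none or still open, it means among the compounds named here.

Compound 1 `CCCSc1nc(N/N=C/c2ccc(C)cc2)c2nnn(Cc3ccccc3)c2n1` and compound 2 `CCCSc1nc(N/N=C(\C)c2ccccc2O)c2nnn(Cc3ccc(O)cc3)c2n1` share one core and differ in several places at once, so no single step can be read between them. In a functional assay on MGC-803 cells (Homo sapiens) for antiproliferative activity, read by MTT assay, with a stated time of 72 h (on this read-out lower numbers stand for stronger inhibition and higher numbers for weaker inhibition), compound 1 is reported only as a limit of the assay, > 64000 nM, and not as a number. In this assay compound 2 gives 7680 nM. The only thing that can be said of compound 1 on the numbers shown is that it sits at the assay limit, (the limit of > 64000 nM in this assay, at which 1 of the 2 values shown sits), and so its true value is unknown.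

Compound 3 `CCCSc1nc(N/N=C/c2ccc3ccccc3c2)c2nnn(Cc3ccccc3)c2n1` has not been measured. It differs from compound 1 in one place: naphthalen-2-yl in place of 4-methylphenyl on a carbon with a double bond to nitrogen. Among the measured compounds shown here, with no measured step between one-place neighbours, and with compound 1 known only as a limit, no direction can be fixed from the data; a modest change is expected, if any, with a fair chance that compound 3 again returns only a limit. Compound 3 is estimated at 40000 nM in this assay, with a range from 8000 nM to 64000 nM, which as a step is expected to be an at least 1.6-fold lower number from compound 1 to compound 3 (0.20 log units; that floor lies within the scatter).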

Compound 3, half-maximal inhibitory concentration: > 64000 nM
Compound 3 was reported as a limit (the forecaster's own chance of this, stated with the estimate: 45%); middle value at least 1.6-fold (0.20 log units) away from the limit.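

Compound 1 and compound 3 are each reported in this assay only as a limit and not as a number, so no step can be read between them: the limit of > 64000 nM in this assay, at which 2 of the 3 values shown sit.

The compounds shown leave open whether naphthalen-2-yl in place of 4-methylphenyl on a carbon with a double bond to nitrogen changes the inhibition at all.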